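A few compounds are considered here, and "the series" means these few. Any claim that something is new, unique, unknown or untested is made for them only; others in the source may bear on it.

Three compounds of the series have numbers in a functional assay on CCRF-CEM cells (Homo sapiens) for inhibition, read by cell counting, with a stated time of 72 h; a lower number here means a stronger inhibitor, a higher number a weaker inhibitor. Compound 1 `CCN(CC)CN1C(=O)/C(=N/NC(N)=S)c2ccccc21` gives 164000 nM. Compound 3 `CCN(CC)CN1C(=O)/C(=N/NC(=S)Nc2ccc(Cl)cc2)c2ccccc21` gives 10000 nM, and the step of a 16-fold lower number from compound 1 to compound 3 (1.21 log units; beyond the scatter) is the larger of the two measured steps. Compound 2 `CCN(CC)CN1C(=O)/C(=N/NC(=S)Nc2ccc(Cl)cc2)c2cc(Cl)ccc21` reaches only a limit of this assay, > 125000 nM, so for compound 2 there is a boundary and not a number. One of the three values sits at the limit of > 125000 nM in this assay, at which 1 of the 3 values shown sits. The other measured step, an at least 12-fold lower number from compound 2 to compound 3 (1.09 log units; beyond the scatter), runs toward a smaller number with hydrogen in place of chloro on an aromatic carbon of the shared core.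

Compound 4 `CCN(CC)CN1C(=O)/C(=N/NC(=S)Nc2ccc(OC)cc2)c2cc(Cl)ccc21` keeps the chloro on the shared core that compound 2 carries and differs from compound 2 by methoxy in place of chloro on an aromatic carbon. Neither measured step touches that site: a 16-fold lower number from compound 1 to compound 3 (1.21 log units; beyond the scatter) introduces the whole 4-chlorophenyl, and an at least 12-fold lower number from compound 2 to compound 3 (1.09 log units; beyond the scatter) alters the shared core. For the measured compounds named here, no step therefore argues for compound 4 moving far from where compound 2 stands. Compound 4 is expected near the limit, with the step of an at least 1.2-fold lower number from compound 2 to compound 4 (0.09 log units; that floor lies within the scatter) expected to be small or none beyond the scatter. The estimate for compound 4 is 100000 nM, between 30000 nM and 300000 nM.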

Compound 4, half-maximal inhibitory concentration: 6900 nM
The estimate for compound 4 lay 14-fold (1.16 log units) above the measured number; the whole stated range lies above it.
By their numbers in this assay, from the lowest: compounds 4 and 3 (each within the scatter of the next); then compound 1.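

Swapping 4-chlorophenyl for 4-methoxyphenyl gives an at least 18-fold lower number from compound 2 to compound 4 (1.25 log units; beyond the scatter) in this assay, so this site, untouched by the earlier steps, can carry a large change on its own. The chloro on the shared core does not by itself prevent a measured number: compound 4 keeps it and gives 6900 nM. The size of the step is only a floor, because compound 2 stands at a limit and not at a number: the limit of > 125000 nM in this assay, at which 1 of the 4 values shown sits.

Open, from the compounds shown here alone, is whether methoxy at this position gives a similar step on the core with hydrogen in place of chloro. Also open, going by these compounds, is how an ethoxy, a dimethylamino or a carboxylic acid would read at the same position.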